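Shortening the amino acid chain on the quinone series

A few compounds are considered here, and "the series" means these few. Any claim that something is new, unique, unknown or untested is made for them only; others in the source may bear on it.

Compound 1 `CC1=CCC[C@H]2[C@](C)(CC3=CC(=O)C=C(NCCC(=O)O)C3=O)[C@@H](C)CC[C@]12C` carries the terpenoid core linked to a quinone bearing a (2-carboxyethyl)amino group. In a functional assay on HeLa cells (Homo sapiens) for cytotoxicity, read by MTT assay, with a stated time of 72 h (on this read-out higher numbers stand for weaker inhibition and lower numbers for stronger inhibition), compound 1 gives 8870 nM, the lowest of the three numbers recorded here. The two compounds without the terpenoid core sit well apart: compound 2 `CC(C)[C@@H](NC1=CC(=O)C=C(C(C)(C)C)C1=O)C(=O)O` gives 96600 nM in this assay, and compound 3 `CSCC[C@H](NC1=CC(=O)C=C(C(C)(C)C)C1=O)C(=O)O` gives 77400 nM in this assay; both gaps to compound 1 lie beyond the scatter.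

Compound 4 `CC1=CCC[C@H]2[C@](C)(CC3=CC(=O)C=C(NCC(=O)O)C3=O)[C@@H](C)CC[C@]12C` keeps the core of compound 1 and differs only in the side chain on the amine: carboxy in place of carboxymethyl on a saturated chain carbon bound to an amine nitrogen. Among the compounds with values here, no measured pair in this set shows the same change, so its effect on this assay is not known from the numbers at hand. Compound 1 and compound 4 share the whole quinone-terpenoid part, and a change of one chain carbon is expected to shift this assay little, if at all, with no clear direction.

For compound 4 the estimate in this assay is 10000 nM, with a range of 4000 nM to 25000 nM, which is expected to mean a step of a 1.1-fold higher number from compound 1 to compound 4 (0.05 log units; within the scatter).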

Compound 4, half-maximal inhibitory concentration: 19900 nM
Estimate against measurement, compound 4: 2.0-fold (0.30 log units) below; measured number inside the range.
By their numbers in this assay, from the lowest: compound 1; then compound 4; then compounds 3 and 2 (each within the scatter of the next).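

In this assay, within the data shown here, the change from 2-carboxyethyl to carboxymethyl on the amine, with the shared core untouched, gives a 2.2-fold higher number from compound 1 to compound 4 (0.35 log units; beyond the scatter) as the first step that can be read in one place. The side chain is therefore not silent on this read-out: the shorter chain goes with weaker inhibition, a modest shift that rests on this single pair. No measurement at hand explains the shift.

The compounds shown leave open whether a chain longer than 2-carboxyethyl, such as 3-carboxypropyl, would lower the number further or reverse the direction. They also leave open whether a methyl ester or a primary amide in place of the carboxylic acid would keep the number of compound 1.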